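The source may hold more compounds than are shown below. What is called first, only, known or untested is meant among the compounds shown, and "the series" means these compounds.

Compound 1, `C/C(=N\NC(N)=S)c1sc(C)nc1C` — in a toxicity assay on THP-1 cells (Homo sapiens) for cytotoxicity, read by MTT assay (on this read-out lower numbers stand for stronger inhibition of growth and higher numbers for weaker inhibition of growth), compound 1 gives > 100 ug/mL, a limit of the assay.
Compound 2, `C/C(=N\Nc1nc(-c2ccccc2)cs1)c1sc(C)nc1C` — in this assay compound 2 gives > 100 ug/mL, a limit of the assay.
Compound 3, `C/C(=N\Nc1nc(-c2ccccc2)cs1)c1sc(-c2ccccc2)nc1C` — in this assay compound 3 gives > 100 ug/mL, a limit of the assay.

Compound 3 stands where the other two measured compounds stand: all three values sit at the limit of > 100 ug/mL in this assay, at which 3 of the 3 values shown sit, so no number distinguishes any of them. Among the compounds with values here, the one step that can be drawn between neighbours, a step that the two limits leave unreadable from compound 2 to compound 3, is likewise unreadable, since both ends are limits.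

Compound 4, `C/C(=N\Nc1nc(-c2ccc(C)cc2)cs1)c1sc(-c2ccccc2)nc1C`, differs from compound 3 by methyl in place of hydrogen on an aromatic carbon; cut one bond further out, the change reads phenyl to 4-methylphenyl. Within the data shown here, no measured step bears on this change, and the only step available, a step that the two limits leave unreadable from compound 2 to compound 3, gives no size at all. With every value shown resting at the limit of > 100 ug/mL in this assay, at which 3 of the 3 values shown sit, compound 4 is expected to remain at the same limit, and the step that the limit leaves unreadable from compound 3 to compound 4 is estimated as none beyond the scatter. Compound 4 is therefore estimated at 120 ug/mL, within a range from 60 ug/mL to 250 ug/mL, with the measurement expected most likely to be reported as a limit only.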

Compound 4, concentration for 50% growth inhibition: > 100 ug/mL
Compound 4 was reported as a limit; the forecaster's own chance of this, stated with the estimate: 80%; the middle value does not contradict the limit.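

No step can be read between compound 3 and compound 4, as both rest at a limit in this assay: the limit of > 100 ug/mL in this assay, at which 4 of the 4 values shown sit.

The compounds shown leave open how any of these structural changes affects growth inhibition, as none of them gives a readable number.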